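The source may report more compounds than this note shows. Statements on the series, on what has been measured and on what is new or still open speak of the compounds shown alone.

Compound 1 `Cc1cc(C)c(S(=O)(=O)N2CCC(N3CCC(O)CC3)CC2)c(C)c1` gives in an ADME assay on HCT-116 cells (Homo sapiens) for cytotoxicity, read by CellTiter-Glo, with a stated time of 72 h (a higher number here means a weaker inhibitor, a lower number a stronger inhibitor), only a limit, > 5000 nM.
Compound 2 `CC1CCN(C2CCN(C(=O)c3ccc(OC(F)(F)F)cc3)CC2)CC1` gives in this assay only a limit, > 5000 nM.
Compound 3 `CC1CCN(C2CCN(S(=O)(=O)c3nccn3C)CC2)CC1` gives in this assay only a limit, > 10000 nM.

None of the three values is a number. Compound 1 sits at the limit of > 5000 nM in this assay, at which 2 of the 3 values shown sit, the same limit as compound 2, while compound 3 sits at the limit of > 10000 nM in this assay, at which 1 of the 3 values shown sits. Compound 4 `Cc1cc(C)c(S(=O)(=O)N2CCC(N3CCN(C)CC3)CC2)c(C)c1` differs from compound 1 by one change: 4-methylpiperazin-1-yl in place of 4-hydroxypiperidin-1-yl on a saturated ring carbon. No measured step between any two of these compounds exists, so the size of this step cannot be read from them. Compound 4 is expected to remain at the limit in this assay, giving no step beyond the scatter as a step that the limit leaves unreadable from compound 1 to compound 4. The estimate for compound 4 is 8000 nM, with a range from 3000 nM to 30000 nM.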

Compound 4, half-maximal inhibitory concentration: > 5000 nM
Compound 4: no number, only a limit; the forecaster's own chance of this, stated with the estimate: 85%; the middle value does not contradict the limit.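

In this assay compound 1 and compound 4 both give only a limit, so the step between them cannot be read. The compounds shown leave open whether 4-methylpiperazin-1-yl in place of 4-hydroxypiperidin-1-yl changes the result at all.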